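This account rests on a few compounds, and the source may have more. Where it says the series, first, only, none or still open, it means among the compounds named here.

Compound 3 `CCCCCCCCc1ccc(OCC(=O)Cn2nnnc2-c2cccnc2)cc1` gives 190 nM in an assay on microsomes from brain for inhibition of Fatty-acid amide hydrolase 1 (Rattus norvegicus), read by fluorescence and HPLC, with a stated time of 60 min; a higher number here means a weaker inhibitor, a lower number a stronger inhibitor; compound 2 `CCCCCCCCc1ccc(OCC(=O)Cn2nnnc2-c2ccncc2)cc1` gives 190 nM, and compound 1 `CCCCCCCCc1ccc(OCC(=O)Cn2nnnc2-c2ccc(Cl)cc2)cc1` gives 130 nM. Compound 3 stands level with compound 2 at the digits shown, the pair together being the highest of the three numbers, and the step of a 1.5-fold higher number from compound 1 to compound 3 (0.16 log units; within the scatter) is within the scatter. Compound 4 `CCCCCCCCc1ccc(OCC(=O)Cn2nnnc2Cc2ccccc2)cc1` differs from compound 3 by benzyl in place of pyridin-3-yl on an aromatic carbon. The measured steps that bear on this change are all exchanges of the group on that same carbon: a 1.5-fold higher number from compound 1 to compound 2 (0.16 log units; within the scatter), a 1.5-fold higher number from compound 1 to compound 3 (0.16 log units; within the scatter) and no change at the digits printed from compound 2 to compound 3 (within the scatter), each within the scatter. Going by the values given here, no measured step brings in benzyl, so the expectation rests on those exchanges alone. The step of no change at the digits printed from compound 3 to compound 4 (within the scatter) is therefore expected to stay within the scatter. Compound 4 is estimated at 190 nM, with a range from 80 nM to 450 nM.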

Compound 4, half-maximal inhibitory concentration: 320 nM
Compound 4: the middle estimate sits 1.7-fold (0.23 log units) below what was measured, and the stated range covers the measured number.
By their numbers in this assay, from the lowest: compounds 1, 2, 3 and 4 (each within the scatter of the next, the first and the last beyond it).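

Benzyl gives the first step at this position beyond the scatter (a 2.5-fold higher number from compound 1 to compound 4 (0.39 log units; beyond the scatter)), and that step is modest. Against the two pyridinyl compounds, it stays within the scatter (a 1.7-fold higher number from compound 3 to compound 4 (0.23 log units; within the scatter)) and (a 1.7-fold higher number from compound 2 to compound 4 (0.23 log units; within the scatter)). Going by these compounds alone, all four groups on this carbon therefore fall within a narrow span, with only the pair of compound 1 and compound 4 separated. No evidence at hand bears on this result. As far as these compounds go, it remains open how an amine, a carboxylic acid or a phenethyl group at this position would compare.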